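Carbamate capping of the aniline nitrogen in a biaryl series

This account rests on a few compounds, and the source may have more. Where it says the series, first, only, none or still open, it means among the compounds named here.

Measured compounds:
Compound 1 `CCOC(=O)c1ccc(-c2ccc(OCC)cc2)o1`: 50000 nM
Compound 2 `CN(C)c1ccc(-c2cccc(N)c2)cc1`: 100000 nM
Compound 3 `CC(C)COC(=O)Nc1cccc(-c2ccc(N(C)C)cc2)c1`: 22000 nM

In an assay on COS-7 cells for inhibition of patatin-like phospholipase domain-containing protein 2 (Mus musculus) (on this read-out lower numbers stand for stronger inhibition and higher numbers for weaker inhibition), compound 2 gives 100000 nM, the highest number of the three; compound 1 sits within the scatter of it, while compound 3 lies beyond the scatter. The step to compound 4 `CCOC(=O)N(C)c1cccc(-c2ccc(N(C)C)cc2)c1` is (ethoxycarbonyl)(methyl)amino in place of amino on an aromatic carbon, so the free amino group of compound 2 is both acylated and methylated. Among the compounds with values here, one measured step bears on this: a 4.5-fold lower number from compound 2 to compound 3 (0.66 log units; beyond the scatter), where an isobutoxycarbonyl group replaced hydrogen on the same nitrogen. Within the data shown here, compound 4 carries a shorter ethoxycarbonyl group and, in addition, a methyl on the nitrogen, which removes the remaining hydrogen-bond donor; no measured pair shows the effect of that methyl. A step of similar size and direction is therefore expected, because the carbamate in a 4.5-fold lower number from compound 2 to compound 3 (0.66 log units; beyond the scatter) gave a modest gain. Compound 4 is estimated at 25000 nM, with a range of 8000 nM to 80000 nM. This estimate means an expected step of a 4.0-fold lower number from compound 2 to compound 4 (0.60 log units; beyond the scatter).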

Compound 4, half-maximal inhibitory concentration: > 200000 nM
Compound 4 ended at the assay's limit; the forecaster's own chance of this, stated with the estimate: 15%; middle value at least 8.0-fold (0.90 log units) away from the limit.
By their numbers in this assay, from the lowest: compound 3; then compounds 1 and 2 (each within the scatter of the next). At a limit, above all of these: compound 4.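

In this assay compound 4 stands at a limit of the assay, > 200000 nM, which is a limit and not a number: the limit of > 200000 nM in this assay, at which 1 of the 4 values shown sits. Capping this nitrogen with a carbamate therefore does not bring a lower number in every case: the change to (ethoxycarbonyl)(methyl)amino gives an at least 2.0-fold higher number from compound 2 to compound 4 (0.30 log units; that floor lies within the scatter), whereas the isobutoxycarbonyl change gave a 4.5-fold lower number from compound 2 to compound 3 (0.66 log units; beyond the scatter). The floor of the new step lies within the scatter, so a rise is not established, but the gain seen with compound 3 does not carry over to compound 4.

The compounds shown do not separate the methyl on the nitrogen from the shorter ethoxycarbonyl group as the source of this difference. Also open, from the compounds shown here alone, is how an acetyl group or a longer alkoxycarbonyl chain on this nitrogen would read in this assay.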